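Swapping the benzyl group on a sulfur-linked growth inhibitor

This account rests on a few compounds, and the source may have more. Where it says the series, first, only, none or still open, it means among the compounds named here.

In a functional assay on DU-145 cells (Homo sapiens) for inhibition, read by trypan blue exclusion, with a stated time of 96 h (on this read-out higher numbers stand for weaker inhibition of growth and lower numbers for stronger inhibition of growth), compound 3 (`CN(C)c1ccc(/C=C(/SCc2ccc(Cl)cc2Cl)C(=O)c2ccc(Cl)cc2)cc1`) gives 50000 nM. Within the data shown here, that is the higher of the two true numbers so far, since compound 2 (`O=C(/C(=C\c1ccc(Br)cc1)SCc1ccc(F)cc1)c1ccc(Cl)cc1`) gives 9000 nM, a gap beyond the usual scatter. The third measured molecule is compound 1 (`CN(C)c1ccc(/C=C(/SCc2ccc(Cl)cc2)C(=O)c2ccc(Cl)cc2)cc1`). Compound 1 gives > 100000 nM, which is a limit of the assay and not a number.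

The next molecule, compound 4 (`CN(C)c1ccc(/C=C(/SCc2ccc(F)cc2)C(=O)c2ccc(Cl)cc2)cc1`), keeps the shared core of compound 3 and changes one group: 4-fluorophenyl in place of 2,4-dichlorophenyl on a saturated chain carbon bound to a sulfur. In words, 4-fluorophenyl takes the place of 2,4-dichlorophenyl on a saturated chain carbon bound to a sulfur.

Among the measured compounds shown here, only one measured step touches this part of the molecule. It is an at least 2.0-fold lower number from compound 1 to compound 3 (0.30 log units; that floor lies within the scatter), where a chloro replaces a hydrogen on an aromatic carbon. That step rests on a limit, so its true size is unknown, and what is shown does not clear the scatter. It therefore gives no firm direction for the swap to fluorine, and no step beyond the scatter is expected.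

The estimated change is no change at the digits printed from compound 3 to compound 4 (within the scatter). For compound 4 the expected value is 50000 nM, with an estimated range from 15000 nM to 100000 nM.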

Compound 4, concentration for 50% growth inhibition: 50000 nM
The estimate for compound 4 equals the measured number at the digits printed, within the range that was stated.
By their numbers in this assay, from the lowest: compound 2; then compounds 3 and 4 (each within the scatter of the next). At a limit, above all of these: compound 1.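

In this assay, putting 4-fluorophenyl in place of 2,4-dichlorophenyl on a saturated chain carbon bound to a sulfur gives no change at the digits printed from compound 3 to compound 4 (within the scatter), so this pair shows that the exchange leaves the read-out unmoved when the rest of the molecule stays the same. Compound 4 also opens a comparison at a second place in the molecule, where dimethylamino in place of bromo on an aromatic carbon gives a 5.6-fold higher number from compound 2 to compound 4 (0.74 log units; beyond the scatter), a modest step beyond the scatter and, in these two pairs, a larger shift than the benzyl swap produces. Fluoro in place of chloro on an aromatic carbon gives an at least 2.0-fold lower number from compound 1 to compound 4 (0.30 log units; that floor lies within the scatter), but that step starts from a limit of the assay and not a number, so its true size remains unknown: the limit of > 100000 nM in this assay, at which 1 of the 4 values shown sits.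

Among these compounds, whether the benzyl swap would stay just as flat with bromo in place of dimethylamino remains open, since the one pair that reads it cleanly carries dimethylamino. Also open, as far as these compounds go, is what an amine or a carboxylic acid on the benzyl ring would do, or a longer chain in place of the saturated chain carbon bound to a sulfur.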